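Solubility notes on aryl-pyrrole series: compound 4 estimate

The source may hold more compounds than are shown below. What is called first, only, known or untested is meant among the compounds shown, and "the series" means these compounds.

Measured so far in a physicochemical assay for solubility, read by nephelometry, in phosphate buffer, measured as kinetic solubility, at pH 6.5; on this read-out lower numbers stand for lower solubility and higher numbers for higher solubility:
- compound 1 `CCOC(=O)C1=C(C)N/C(=C/c2cc(C)n(-c3ccc(F)cc3F)c2C)C1=O`: 6.3 ug/mL
- compound 2 `CCOC(=O)C1=C(C)N/C(=C/c2cc(C)n(-c3ccc(OC)cc3)c2C)C1=O`: 3.1 ug/mL
- compound 3 `CCOC(=O)C1=C(C)N/C(=C/c2cc(C)n(-c3ccc(SC(F)(F)F)cc3)c2C)C1=O`: 1 ug/mL

Compound 2 stands second highest of the three numbers in this assay; compound 1 sits above it by a 2.0-fold lower number from compound 1 to compound 2 (0.31 log units; beyond the scatter) read backwards, and compound 3 sits below it by a 3.1-fold lower number from compound 2 to compound 3 (0.49 log units; beyond the scatter).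

Compound 4 `CCOC(=O)C1=C(C)N/C(=C/c2cc(C)n(-c3cccnc3)c2C)C1=O` has not yet been measured. Its change from compound 2 is pyridin-3-yl in place of 4-methoxyphenyl on an aromatic nitrogen. Neither measured step bears directly on this change: a 2.0-fold lower number from compound 1 to compound 2 (0.31 log units; beyond the scatter) swapped one substituted phenyl for another on the same aromatic nitrogen, and a 3.1-fold lower number from compound 2 to compound 3 (0.49 log units; beyond the scatter) swapped a substituent on the phenyl ring. Going by the values given here, both steps were modest and beyond the scatter, but no measured pair introduces a ring hetero atom into the group on the aromatic nitrogen.

With only these two steps as a guide, a modest step is expected in this assay, more likely upward than downward, as a 2.9-fold higher number from compound 2 to compound 4 (0.46 log units; beyond the scatter). Compound 4 is accordingly estimated at 9 ug/mL, with a range from 3 ug/mL to 30 ug/mL.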

Compound 4, solubility: 25 ug/mL
For compound 4 the middle estimate is 2.8-fold (0.44 log units) below the measured one; the measured number falls inside the stated range.
By their numbers in this assay, from the lowest: compound 3; then compound 2; then compound 1; then compound 4.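

In this assay the pyridin-3-yl group on the aromatic nitrogen, the only group shown with a hetero atom in that ring, gives an 8.1-fold higher number from compound 2 to compound 4 (0.91 log units; beyond the scatter) and also a 4.0-fold higher number from compound 1 to compound 4 (0.60 log units; beyond the scatter) in the same direction. The changes among phenyl groups gave smaller steps, namely a 2.0-fold lower number from compound 1 to compound 2 (0.31 log units; beyond the scatter) and a 3.1-fold lower number from compound 2 to compound 3 (0.49 log units; beyond the scatter), so this position tolerates a much larger upward move in this read-out than those compounds showed. Nothing measured here explains the size of the step.

Both new steps replace the ring and remove its substituents at once, so the share of the ring nitrogen and the share of the lost methoxy or fluoro groups stay unseparated. An unsubstituted phenyl, a pyridin-4-yl, or a pyridin-3-yl carrying a methoxy group on the same nitrogen would show whether the rise follows the ring nitrogen itself.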